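Replacing the aryl group of compound 1

A few compounds are considered here, and "the series" means these few. Any claim that something is new, unique, unknown or untested is made for them only; others in the source may bear on it.

Among the measured compounds shown here, in a functional assay on MCF7 cells (Homo sapiens) for antiproliferative activity, read by MTT assay, with a stated time of 72 h (on this read-out lower numbers stand for stronger inhibition and higher numbers for weaker inhibition), compound 1 `CCNC(=O)c1cc(Oc2ccc(NC(=O)c3nn(-c4ccccc4OC(F)(F)F)c(=O)cc3C)cc2)ccn1` gives 15500 nM, the lower of the only two numbers available for the series. Compound 3 `CCCNC(=O)c1cc(Oc2ccc(NC(=O)c3nn(-c4ccccc4C)c(=O)cc3C)cc2F)ccn1` gives 39600 nM, a higher number, and that gap lies beyond the scatter. Compound 2 `CCCNC(=O)c1cc(Oc2ccc(NC(=O)c3nn(-c4ccc(Br)cc4F)c(=O)cc3C)cc2F)ccn1` is recorded as "not active" (no number reported), with no number reported. For the measured compounds named here, no two measured compounds differ in one place only, so the series offers no measured step for a single change.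

Compound 4 `CCNC(=O)c1cc(Oc2ccc(NC(=O)c3nn(-c4cccc(C(F)(F)F)c4)c(=O)cc3C)cc2)ccn1` keeps the rest of compound 1 and carries 3-(trifluoromethyl)phenyl in place of 2-(trifluoromethoxy)phenyl on an aromatic nitrogen. The expectation rests on thin evidence and leans slightly upward. Compound 1 sits at the low end with 15500 nM, while compound 3, with another group on that nitrogen, reaches 39600 nM. Compound 2 also shows that a change at this group can leave no number at all, and that outcome remains possible for compound 4. In this assay the expected 1.4-fold higher number from compound 1 to compound 4 (0.15 log units; within the scatter) is small, towards a higher number and within the scatter. For compound 4 the estimated value is 22000 nM, with an expected range from 8000 nM to 60000 nM.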

Compound 4, half-maximal inhibitory concentration: 40600 nM
Compound 4: middle estimate off by 1.8-fold (0.27 log units), on the low side; low and high end bracket the measured number.
By their numbers in this assay, from the lowest: compound 1; then compounds 3 and 4 (each within the scatter of the next).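

In this assay, among the compounds shown here, the exchange of 2-(trifluoromethoxy)phenyl for 3-(trifluoromethyl)phenyl on the aromatic nitrogen gives the first readable single change: a 2.6-fold higher number from compound 1 to compound 4 (0.42 log units; beyond the scatter). For the compounds shown here, with the rest of compound 1 held fixed, this shows that the group on this nitrogen alone can shift the number towards weaker inhibition, which the earlier compounds, differing from one another in more than one place, could not show. The two group names differ both in the substituent and in where it stands on the phenyl ring, and no measurement here bears on why the number moves.

Going by these compounds, it remains open how much of the step belongs to the substituent and how much to its location on the phenyl ring, a question that 3-(trifluoromethoxy)phenyl or 2-(trifluoromethyl)phenyl on this nitrogen would address. Also open, on these data alone, is how this position responds to a different kind of group, such as a phenyl ring carrying a carboxylic acid or an amine, and whether any such group would bring the number below that of compound 1.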